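Ring Closure at the Amide Nitrogen: What Compound 3 May Show

A few compounds are considered here, and "the series" means these few. Any claim that something is new, unique, unknown or untested is made for them only; others in the source may bear on it.

Compound 1 `CCCn1c(=O)c2nc([C@]34CC[C@](C(=O)NCCN(C)C)(CC3)CC4)[nH]c2n(CCC)c1=O` and compound 2 `CCCn1c(=O)c2nc([C@]34CC[C@](C(=O)NCC(=O)O)(CC3)CC4)[nH]c2n(CCC)c1=O` share one core and differ only at the end of the amide chain. In an assay on CHO-K1 cells for displacement of a labelled ligand from adenosine receptor A1 (Homo sapiens) (on this read-out lower numbers stand for stronger inhibition and higher numbers for weaker inhibition), compound 1 gives 6 nM, whereas compound 2 gives 49 nM. For the measured compounds named here, the single measured step, an 8.2-fold higher number from compound 1 to compound 2 (0.91 log units; beyond the scatter), leaves compound 2 with the highest of the two numbers so far. Compound 3 `CCCn1c(=O)c2nc([C@]34CC[C@](C(=O)N5CCC(C(=O)O)CC5)(CC3)CC4)[nH]c2n(CCC)c1=O` has not yet been measured; against compound 2 it carries 4-carboxypiperidin-1-yl in place of (carboxymethyl)amino on a carbonyl carbon. Going by the values given here, no measured step covers this particular change. The carboxy group is retained in compound 3, and the amide nitrogen becomes part of the six-membered ring. The step from compound 1 to compound 2 shows how much the exchange of (dimethylamino)methyl for carboxy cost in this assay, but it gives no guide to what folding the amide nitrogen into a ring does. With the carboxy kept, for compound 3 the expected step in this assay is a 1.2-fold higher number from compound 2 to compound 3 (0.09 log units; within the scatter), essentially no change beyond the scatter. Compound 3 is therefore estimated at 60 nM, within a range from 20 nM to 200 nM.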

Compound 3, inhibition constant: 96 nM
Compound 3: middle estimate off by 1.6-fold (0.20 log units), on the low side; the measured number falls inside the stated range.
By their numbers in this assay, from the lowest: compound 1; then compounds 2 and 3 (each within the scatter of the next).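

In this assay, 4-carboxypiperidin-1-yl in place of (carboxymethyl)amino on the carbonyl carbon gives a 2.0-fold higher number from compound 2 to compound 3 (0.29 log units; within the scatter), so with the carboxy kept, this position accepts the six-membered non-aromatic ring and the loss of the open chain without a step beyond the scatter. Set against the basic reference point of the series, the same ring-bearing acid gives a 16-fold higher number from compound 1 to compound 3 (1.20 log units; beyond the scatter), which places compound 2 and compound 3 together on the side of higher numbers, apart from compound 1, and no compound shown goes against this. Nothing available explains these readings at this position.

The compounds shown leave open whether the gap to compound 1 goes with the carboxy alone or would survive in a ring as well, since no ring here carries an amine: a 4-(dimethylamino)piperidin-1-yl group on the same carbonyl carbon would test that directly. An unsubstituted piperidin-1-yl group, or a longer open chain such as (3-carboxypropyl)amino, would show separately what the ring and the distance to the carboxy contribute.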